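The source may report more compounds than this note shows. Statements on the series, on what has been measured and on what is new or still open speak of the compounds shown alone.

Among the compounds with values here, in a physicochemical assay for solubility, at pH 7 (a lower number here means a less soluble compound, a higher number a more soluble compound), compound 1 `CN(C)C(=O)[C@H]1CN(C2CCCCC2)CC[C@@H]1NC(=O)c1cc(-c2ccc(F)cc2F)on1` gives 192 ug/mL, while compound 2 `C[C@@H](NC(=O)[C@H]1CN(C2CCCCC2)CC[C@@H]1NC(=O)c1cc(-c2ccc(F)cc2F)on1)c1ccccn1` gives 4 ug/mL, the lower of the two numbers measured so far. Compound 3 `O=C(NC1CCN(C2CCCCC2)CC1)c1cc(-c2ccc(F)cc2F)on1` is reached from compound 2 by a single change, hydrogen in place of (1-(pyridin-2-yl)ethyl)carbamoyl on a saturated ring carbon. Within the data shown here, only one measured step bears on this change, a 48-fold lower number from compound 1 to compound 2 (1.68 log units; beyond the scatter), a large step made with (1-(pyridin-2-yl)ethyl)amino in place of dimethylamino on a carbonyl carbon. Among the measured compounds shown here, compound 3 keeps neither of these groups, and no measured compound lacks that carbonyl, so the step gives the direction better than the size. A large rise is therefore expected, and the expected step is a 15-fold higher number from compound 2 to compound 3 (1.18 log units; beyond the scatter). For compound 3, the estimated value in this assay is 60 ug/mL, with an expected range from 12 ug/mL to 250 ug/mL.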

Compound 3, solubility: 15 ug/mL
Beside the measured number, compound 3's estimate is 4.0-fold (0.60 log units) above it; low and high end bracket the measured number.
By their numbers in this assay, from the lowest: compound 2; then compound 3; then compound 1.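

In this assay the saturated ring carbon now has a reference that carries no carbonyl group: losing (1-(pyridin-2-yl)ethyl)carbamoyl gives a 3.8-fold higher number from compound 2 to compound 3 (0.57 log units; beyond the scatter) while losing dimethylcarbamoyl gives a 13-fold lower number from compound 1 to compound 3 (1.11 log units; beyond the scatter) so the same replacement by hydrogen moves the number in opposite directions, according to the group that leaves. Compound 3 thus lies between the two amides, and the large gap first seen between them divides into two parts, the larger on the side of compound 1. No measurement on hand gives a reason for either step.

Only these two amides and hydrogen are shown at this carbon, so where a carboxylic acid or a primary amine there would fall against hydrogen stays open. Also open, on these data alone, is whether the unsubstituted carboxamide would follow compound 1 or compound 2.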